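Swapping a methoxy for methylpiperazine on a kinase scaffold

This account rests on a few compounds, and the source may have more. Where it says the series, first, only, none or still open, it means among the compounds named here.

Measured so far:
compound 1 `Nc1n[nH]c2cc(-c3cccnc3)[nH]c(=O)c12`: 27%
compound 2 `COc1ccc(-c2cc3[nH]nc(N)c3c(=O)[nH]2)cc1`: 43%

Both compounds share one core and were tested in an assay on isolated protein for inhibition of serine/threonine-protein kinase Chk2 (Homo sapiens), read by mobility shift assay, tested at 30 uM; on this read-out higher numbers stand for more inhibition at the one concentration tested (going by the name of the read-out) and lower numbers for less inhibition. Of the two numbers, compound 2 gives the higher one in this assay, and compound 1 sits lower by more than the usual scatter. Compound 3 `CN1CCN(c2ccc(-c3cc4[nH]nc(N)c4c(=O)[nH]3)cc2)CC1` differs from compound 2 in one place: 4-methylpiperazin-1-yl in place of methoxy on an aromatic carbon. Among the compounds with values here, no measured pair shows what such a swap does here, so no step beyond the scatter is expected in either direction, and the estimated change is a number 2 percentage points higher from compound 2 to compound 3 (within the scatter). Compound 3 is therefore expected to give about 45% in this assay, within a range from 25% to 68%.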

Compound 3, a percentage reported as inhibition, at one concentration (the size of the read-out at that concentration, not a potency): 68%
Compound 3: the middle estimate sits 23 percentage points below what was measured; the measured number falls inside the stated range.
By their numbers in this assay, from the lowest: compound 1; then compound 2; then compound 3.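

On the aromatic carbon para to a large group, 4-methylpiperazin-1-yl in place of methoxy gives a number 25 percentage points higher from compound 2 to compound 3 (beyond the scatter) in this assay. This position therefore accepts a much larger group that carries a ring, and inhibition at the one tested concentration still rises. Nothing measured here accounts for the gain. From the compounds shown here alone, what remains open is which part of the new group matters, and whether the same gain would come with morpholine, piperidine or a simple dimethylamino group on that carbon.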